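The source may report more compounds than this note shows. Statements on the series, on what has been measured and on what is new or still open speak of the compounds shown alone.

Of the compounds shown here, three sharing one core have been measured in a functional assay on CCRF-CEM cells (Homo sapiens) for antiproliferative activity, with a stated time of 72 h; on this read-out lower numbers stand for stronger inhibition and higher numbers for weaker inhibition. Compound 1 `OC[C@H]1O[C@@H](n2cnc3c(NCc4ccc(Cl)cc4)ncnc32)[C@H](O)[C@@H]1O` gives 10200 nM, compound 2 `OC[C@H]1O[C@@H](n2cnc3c(NCc4ccccc4Br)ncnc32)[C@H](O)[C@@H]1O` gives 12300 nM, and compound 3 `OC[C@H]1O[C@@H](n2cnc3c(NCc4ccc(Br)cc4)ncnc32)[C@H](O)[C@@H]1O` gives 20600 nM. Compound 3 thus has the highest number of the three, although only its gap to compound 1 passes the scatter, as a 2.0-fold higher number from compound 1 to compound 3 (0.31 log units; beyond the scatter) shows, while a 1.7-fold higher number from compound 2 to compound 3 (0.22 log units; within the scatter) does not.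

The next compound, compound 4 `Cc1cccc(CNc2ncnc3c2ncn3[C@@H]2O[C@H](CO)[C@@H](O)[C@H]2O)c1`, carries 3-methylphenyl in place of 4-bromophenyl on a saturated chain carbon bound to a nitrogen on an aromatic ring. Within the data shown here, no measured compound carries a methyl group, so the data offer no direct precedent for this change. The nearest evidence comes from the other changes to this aromatic ring. Besides the two steps above, there is a 1.2-fold higher number from compound 1 to compound 2 (0.08 log units; within the scatter). The largest of the three is only modest, so a large shift in this assay would be a surprise. The expected step is a 1.4-fold lower number from compound 3 to compound 4 (0.14 log units; within the scatter), a small move in the direction of lower numbers that is not expected to pass the scatter. Compound 4 is estimated at about 15000 nM, with an expected range of 6000 nM to 38000 nM.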

Compound 4, half-maximal inhibitory concentration: 19100 nM
Compound 4: the middle estimate sits 1.3-fold (0.10 log units) below what was measured; the range from low to high includes it.
By their numbers in this assay, from the lowest: compounds 1, 2, 4 and 3 (each within the scatter of the next, the first and the last beyond it).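

Placing 3-methylphenyl in place of 4-bromophenyl on a saturated chain carbon bound to a nitrogen on an aromatic ring gives a 1.1-fold lower number from compound 3 to compound 4 (0.03 log units; within the scatter) in this assay, so this position accepts a methyl-bearing ring without a halogen and the read-out stays within the scatter. The comparisons with the two other halogen-bearing compounds also stay within it, at a 1.6-fold higher number from compound 2 to compound 4 (0.19 log units; within the scatter) and a 1.9-fold higher number from compound 1 to compound 4 (0.27 log units; within the scatter), which means compound 4 cannot be told apart from any of the three earlier compounds, even though compound 1 and compound 3 are separated by a 2.0-fold higher number from compound 1 to compound 3 (0.31 log units; beyond the scatter). The data shown offer no explanation for how little these replacements move the number.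

Among these compounds, compound 4 is the only compound here with a methyl group, so it remains open whether that group would read the same elsewhere on the ring. Also open, as far as these compounds go, is whether an amine or a carboxylic acid on this ring, or a longer chain carrying the ring in place of the benzyl unit, would move the number out of this narrow band.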